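Adding a second chloro to an anticonvulsant piperazine amide

A few compounds are considered here, and "the series" means these few. Any claim that something is new, unique, unknown or untested is made for them only; others in the source may bear on it.

Measured so far:
Compound 1 `CC1(c2ccccc2)CC(=O)N(CC(=O)N2CCN(c3ccccc3F)CC2)C1=O`: 100 mg/kg
Compound 2 `CC1(c2ccccc2)CC(=O)N(CC(=O)N2CCN(c3ccccc3Cl)CC2)C1=O`: "not active" (no number reported)

Two compounds share the same core and differ only in the halogen on the phenyl attached to the piperazine. In a functional assay on the whole organism (strain CD-1) with Mus musculus as the target, with a stated time of 0.5 h (on this read-out lower numbers stand for an effect already at smaller amounts and higher numbers for an effect only at larger amounts of compound), compound 1 gives 100 mg/kg. Compound 2, with chloro in place of fluoro on that phenyl, is reported in this assay only as "not active" (no number reported), so no number stands for it, and the two compounds cannot be set against each other as a measured step.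

Compound 3 `CC1(c2ccccc2)CC(=O)N(CC(=O)N2CCN(c3cccc(Cl)c3Cl)CC2)C1=O` is the next compound and has not yet been tested. It is made from compound 2 by chloro in place of hydrogen on an aromatic carbon. Since compound 2 carries no number, no step size can be computed for this change; given that compound 2 shows no effect, the expectation for compound 3 is either again no reported number, or an effect only at a large dose. If a number is obtained, compound 3 is estimated at 300 mg/kg, with a range from 100 mg/kg to 1000 mg/kg.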

Compound 3, minimum effective dose: 300 mg/kg
The estimate for compound 3 equals the measured number at the digits printed; the range from low to high includes it.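

In this assay, compound 2 is reported only as "not active", while compound 3, with chloro in place of hydrogen on the aromatic carbon ortho to the existing chloro, gives 300 mg/kg, so this added chloro goes with a measurable effect, though only at a large dose. The size of this change cannot be read, since compound 2 has no number, but the 2,3-dichlorophenyl group can be set against the 2-fluorophenyl group, where there is a 3.0-fold higher number from compound 1 to compound 3 (0.48 log units; beyond the scatter), meaning that compound 3 needs a larger dose for an effect. No measurement shown here explains either difference.

Going by these compounds, it remains open whether the effect of the added chloro depends on the first chloro, or whether the added chloro alone on that phenyl would also give a measurable dose. On these data alone, it is also open whether a methyl or a methoxy group in the same place would behave like chloro, and whether either could bring the minimum effective dose below that of compound 1.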